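The source may report more compounds than this note shows. Statements on the series, on what has been measured and on what is new or still open speak of the compounds shown alone.

Compound 1 `COc1ccc(S(=O)(=O)N2CCc3cccc(NC(=O)C(C)(C)C)c32)cc1`: 359 nM
Compound 2 `COc1ccc(S(=O)(=O)N2CCc3cccc(NS(=O)(=O)c4ccc(F)cc4)c32)cc1`: 1200 nM
Compound 3 `COc1ccc(S(=O)(=O)N2CCc3cccc(NC(C)=O)c32)cc1`: 89 nM

In a functional assay on KB cells (Homo sapiens) for cytotoxicity (a lower number here means a stronger inhibitor, a higher number a weaker inhibitor), compound 1 stands in the middle of these three numbers. Compound 4 `COc1ccc(S(=O)(=O)N2CCc3cccc(NCc4ccccc4)c32)cc1` differs from it as follows: benzyl in place of (tert-butyl)carbonyl on a nitrogen on an aromatic ring. In short, benzyl takes the place of (tert-butyl)carbonyl on a nitrogen on an aromatic ring. For the measured compounds named here, two measured steps bear on this. The closer is a 3.3-fold higher number from compound 1 to compound 2 (0.52 log units; beyond the scatter), where the entering group also holds an aromatic ring. The other, a 4.0-fold lower number from compound 1 to compound 3 (0.61 log units; beyond the scatter), swaps tert-butyl for methyl and keeps the carbonyl. Going by the values given here, no measured compound lacks a carbonyl or sulfonyl on that nitrogen, so the guidance is loose. A modest rise is expected, estimated as a 2.2-fold higher number from compound 1 to compound 4 (0.35 log units; beyond the scatter). For compound 4 the estimated value is 800 nM, with an expected range of 150 nM to 4000 nM.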

Compound 4, half-maximal inhibitory concentration: > 10000 nM
Compound 4: no number, only a limit (the forecaster's own chance of this, stated with the estimate: 10%); middle value at least 12-fold (1.09 log units) from the limit.
By their numbers in this assay, from the lowest: compound 3; then compound 1; then compound 2. At a limit, above all of these: compound 4.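

In this assay compound 4 gives only a limit: the limit of > 10000 nM in this assay, at which 1 of the 4 values shown sits.

Benzyl therefore gives a weaker result than each group it replaces on this nitrogen: an at least 27-fold higher number from compound 1 to compound 4 (1.44 log units; beyond the scatter), an at least 110-fold higher number from compound 3 to compound 4 (2.05 log units; beyond the scatter) and an at least 8.3-fold higher number from compound 2 to compound 4 (0.92 log units; beyond the scatter). Compounds 1, 2 and 3 all carry a carbonyl or sulfonyl there and give measured values, so an aromatic ring alone, present in both compound 2 and compound 4, does not preserve measurable activity.

Going by these compounds, it remains open whether the drop follows from losing the carbonyl or sulfonyl or from benzyl itself. A plain amine or a methyl on that nitrogen would help separate the two.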